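Distal aryl substitution in a serine phosphodiester series

The source may hold more compounds than are shown below. What is called first, only, known or untested is meant among the compounds shown, and "the series" means these compounds.

Compound 1 `N[C@@H](COP(=O)(O)OCCCOC(=O)CCc1ccccc1OCc1cccc(Oc2ccccc2)c1)C(=O)O` is the reference point of the set. Among the measured compounds shown here, in an assay on cells for agonist activity at probable G-protein coupled receptor 34 (Mus musculus), with a stated time of 1 h (on this read-out lower numbers stand for smaller maximal responses and higher numbers for larger maximal responses), compound 1 gives 19.4%, the second highest of the three numbers so far, with both neighbours within the scatter of it. Compound 2 `Cc1ccccc1Oc1cccc(COc2ccccc2CCC(=O)OCCCOP(=O)(O)OC[C@H](N)C(=O)O)c1` carries a methyl on the distal aromatic ring; in this assay compound 2 gives 20.3%, and the step of a number 0.9 percentage points higher from compound 1 to compound 2 (within the scatter) stays inside the scatter. Compound 3 `N[C@@H](COP(=O)(O)OCCCOC(=O)CCc1ccccc1OCc1cccc(Oc2cccc(Cl)c2)c1)C(=O)O` carries a chloro instead; in this assay compound 3 gives 17.1%, and the step of a number 2.3 percentage points lower from compound 1 to compound 3 (within the scatter) is again inside the scatter, as is the step of a number 3.2 percentage points lower from compound 2 to compound 3 (within the scatter) between the two substituted analogues.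

Compound 4 `Cc1ccccc1-c1ccc(Oc2cccc(COc3ccccc3CCC(=O)OCCCOP(=O)(O)OC[C@H](N)C(=O)O)c2)cc1` differs from compound 1 by 2-methylphenyl in place of hydrogen on an aromatic carbon. For the measured compounds named here, the steps that bear on this are the two small additions on the same distal ring, a number 0.9 percentage points higher from compound 1 to compound 2 (within the scatter) and a number 2.3 percentage points lower from compound 1 to compound 3 (within the scatter), neither of which moved the maximal response beyond the scatter. The entering group here is larger than either, but nothing in the set shows a size-dependent effect, so no step beyond the scatter is expected in this assay for compound 4, in either direction. Compound 4 is therefore expected to give 18% in this assay, estimated within 8% to 30%, which means an expected step of a number 1.4 percentage points lower from compound 1 to compound 4 (within the scatter).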

Compound 4, largest response reached (Emax), in percent of the reference or control that the assay uses: 13.4%
The estimate for compound 4 lay 4.6 percentage points above the measured number; the measured number falls inside the stated range.
By their numbers in this assay, from the lowest: compounds 4, 3, 1 and 2 (each within the scatter of the next).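

In this assay, placing 2-methylphenyl on an aromatic carbon para to a large group gives a number 6 percentage points lower from compound 1 to compound 4 (within the scatter), and this is the largest step from compound 1 in the set so far, though it remains within the scatter. The earlier steps shown here from compound 1 covered only a methyl and a chloro, whereas this one adds 7 heavy atoms and a whole further six-membered aromatic ring, and still the maximal response does not move beyond the scatter. No supporting data bear on why compound 4 reads as it does.

Every step among the compounds shown stays within the scatter, so none of the groups here separates itself from compound 1 on this read-out, and the values do not rank the substituents. Open, on these data alone, is whether an amine or a carboxylic acid on this same aromatic carbon, or a longer chain such as an n-hexyl group in place of the 2-methylphenyl, would give a step from compound 1 beyond the scatter in either direction.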